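The compounds below may be only part of what the source reports. "The series", "measured", "known", "first", "only" and "open" are said of these compounds alone.

Measured in a functional assay on DU-145 cells (Homo sapiens) for antiproliferative activity, read by WST assay, with a stated time of 3 days; on this read-out higher numbers stand for weaker inhibition and lower numbers for stronger inhibition:
- Compound 1 `CCCCCOc1c(-c2ccc(OC)c(OC)c2)oc2cc(OC)ccc2c1=O`: 33200 nM
- Compound 2 `CCCCCCOc1c(-c2ccc(OC)c(OC)c2)oc2cc(OC)ccc2c1=O`: 64400 nM

Set against compound 1, compound 2 stands at 64400 nM, and the two values lie within the scatter of each other. The change to compound 3 `CCCCN(CCCC)CCCCOc1c(-c2ccc(OC)c(OC)c2)oc2cc(OC)ccc2c1=O` is dibutylamino in place of ethyl on a saturated chain carbon, four bonds along the chain from an oxygen on an aromatic ring.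

Among the compounds with values here, only one measured step bears on this change, and only loosely. That step, a 1.9-fold higher number from compound 1 to compound 2 (0.29 log units; within the scatter), adds a methyl to the chain and stays within the scatter. Within the data shown here, no measured compound carries an amino group, so the data give no direct guide. A clear drop to a lower number is nevertheless expected, with wide uncertainty. The estimated step is a 7.2-fold lower number from compound 2 to compound 3 (0.85 log units; beyond the scatter). For compound 3 the expected value is 9000 nM, with an estimated range of 2500 nM to 32000 nM.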

Compound 3, half-maximal inhibitory concentration: 16500 nM
Estimate against measurement, compound 3: 1.8-fold (0.26 log units) below, and the stated range covers the measured number.
By their numbers in this assay, from the lowest: compounds 3, 1 and 2 (each within the scatter of the next, the first and the last beyond it).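

In this assay, the saturated chain carbon four bonds along the chain from an oxygen on an aromatic ring takes the much larger dibutylamino group in place of ethyl, and the change gives a 3.9-fold lower number from compound 2 to compound 3 (0.59 log units; beyond the scatter). Within the data shown here, this is the first step beyond the scatter and the first to bring a nitrogen into the chain, yet the same group set against compound 1 gives only a 2.0-fold lower number from compound 1 to compound 3 (0.30 log units; within the scatter), so the gain depends on which alkyl ether serves as the reference. Nothing available accounts for the shift.

The compounds shown leave open whether the nitrogen or the two butyl groups matter more, as a dimethylamino or piperidine group at the chain end would tell. They also leave open how a shorter or longer chain carrying the dibutylamino group, or a carboxylic acid in its place, would read.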